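Furan-3-yl exchange in a series at the limit

A few compounds are considered here, and "the series" means these few. Any claim that something is new, unique, unknown or untested is made for them only; others in the source may bear on it.

In a functional assay on HT-29 cells (Homo sapiens) for inhibition (on this read-out lower numbers stand for stronger inhibition and higher numbers for weaker inhibition), compound 1 `C(=C/c1ccco1)\c1ccc2ccccc2c1` gives > 5000 nM, which is a limit and not a number. Compound 2 `C(=C\c1ccco1)\c1ccc2ccccc2c1` gives > 5000 nM, also a limit. Compound 3 `C(=C/c1ccc2ccccc2c1)\c1ccoc1` differs from compound 1 by furan-3-yl in place of furan-2-yl on a double-bonded chain carbon bound to a double-bonded chain carbon. Among the measured compounds shown here, the only measured step, a step that the two limits leave unreadable from compound 1 to compound 2, reflects configuration alone (the fact that compounds 1 and 2 differ only in the configuration as drawn), has no readable size and does not test this exchange. In this assay no step beyond the scatter is expected, and the estimated step is a step that the limit leaves unreadable from compound 1 to compound 3. The expected value for compound 3 is 7000 nM, within an estimated range of 2500 nM to 15000 nM.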

Compound 3, half-maximal inhibitory concentration: > 5000 nM
Compound 3 was reported as a limit; the forecaster's own chance of this, stated with the estimate: 75%; the middle value lies beyond the limit too.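

Among the compounds shown here, compound 1 and compound 3 are both reported only as limits, so no step for the furan-3-yl exchange can be read: the limit of > 5000 nM in this assay, at which 3 of the 3 values shown sit.

The compounds shown leave open whether in this assay this exchange changes inhibition at all.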